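The compounds below may be only part of what the source reports. "The series", "measured", "known", "first", "only" and "open" are said of these compounds alone.

Three compounds sharing one core have numbers in an in vitro ADME assay on microsomes from liver (Homo sapiens) for metabolic stability, tested at 1 uM; a lower number here means that the compound disappears faster, a higher number that the compound lasts longer. Compound 1 `Cc1cc(/C=C/C#N)cc(C)c1Oc1cc(Nc2ccc(C#N)cc2)c(N)cc1[N+](=O)[O-]` gives 0.797 h and compound 3 `COC(=O)c1cc(N)c(Nc2ccc(C#N)cc2)cc1Oc1c(C)cc(/C=C/C#N)cc1C` gives 4.72 h in this read-out. Compound 2 `Cc1cc(CCC#N)cc(C)c1Oc1cc(Nc2ccc(C#N)cc2)c(N)cc1CO` gives 0.348 h as the lowest of the three numbers, with compound 1 nearest to it and compound 3 furthest away. Compound 4 `Cc1cc(CCC#N)cc(C)c1Oc1cc(Nc2ccc(C#N)cc2)c(N)cc1C(N)=O` has yet to be measured. It departs from compound 2 in one place, carbamoyl in place of hydroxymethyl on an aromatic carbon is the whole of the difference. Going by the values given here, only one measured step bears on this change, and only indirectly. That step is a 5.9-fold higher number from compound 1 to compound 3 (0.77 log units; beyond the scatter) and it is modest, with methoxycarbonyl in place of nitro on an aromatic carbon. Among the compounds with values here, neither group of the present swap takes part in it, and compounds 1 and 3 also differ from compound 2 elsewhere, so no measured pair isolates hydroxymethyl or carbamoyl. Still, compound 3 at 4.72 h carries a carbonyl group in that place and lies above compound 2, so a modest rise is the expectation. The expected size is a 2.9-fold higher number from compound 2 to compound 4 (0.46 log units; beyond the scatter) in this assay and remains uncertain. Compound 4 is estimated at 1 h with an expected range from 0.35 h to 3 h in this measurement.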

Compound 4, half-life: 0.7 h
Beside the measured number, compound 4's estimate is 1.4-fold (0.15 log units) above it; low and high end bracket the measured number.
By their numbers in this assay, from the lowest: compounds 2, 4 and 1 (each within the scatter of the next, the first and the last beyond it); then compound 3.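

Going by these compounds alone, compounds 2 and 4 form the first pair that isolates this change in this assay, and a 2.0-fold higher number from compound 2 to compound 4 (0.30 log units; within the scatter) places carbamoyl and hydroxymethyl on this aromatic carbon, ortho to a large group and para to a (4-cyanophenyl)amino group, within the scatter of each other. The earlier step at this place, a 5.9-fold higher number from compound 1 to compound 3 (0.77 log units; beyond the scatter), lay beyond the scatter, but it concerned nitro and methoxycarbonyl on a different chain, so the two steps show that the size of the effect at this aromatic carbon is not the same for every pair of groups, without saying which difference between the pairs matters. No measurement at hand gives a reason for this result.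

The compounds shown leave open how a carboxylic acid, a methyl-substituted amide or an aminomethyl group at this place would read in this assay. They also leave open whether carbamoyl in place of hydroxymethyl would give a step of similar size on the core of compound 1, with its unsaturated chain, rather than on that of compound 2.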